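The source may report more compounds than this note shows. Statements on the series, on what has been measured and on what is new or still open speak of the compounds shown alone.

Measured compounds:
compound 1, `Cc1ccc(CCCOC(=O)N(c2ccccc2)C2CN3CCC2CC3)cc1F`: 130 nM
compound 2, `COc1ccc(CCCOC(=O)N(c2ccccc2)C2CN3CCC2CC3)cc1`: 640 nM
compound 3, `COc1ccc(CCCOC(=O)N(c2ccccc2)C2CN3CCC2CC3)cc1F`: 260 nM

All three numbers come from an assay on CHO cells for displacement of a labelled ligand from muscarinic acetylcholine receptor M5 (Homo sapiens), read by scintillation counting, with a stated time of 2 h; on this read-out higher numbers stand for weaker inhibition and lower numbers for stronger inhibition. Compound 3 stands second highest of the three. Its nearest neighbour is compound 1, with a 2.0-fold higher number from compound 1 to compound 3 (0.30 log units; within the scatter) lying within the scatter, so no order between the two is claimed. Its furthest neighbour is compound 2, where a 2.5-fold lower number from compound 2 to compound 3 (0.39 log units; beyond the scatter) is a modest step beyond the scatter.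

Compound 4, `COc1ccc(CCOC(=O)N(c2ccccc2)C2CN3CCC2CC3)cc1OC`, is not yet measured. Going from compound 3 it carries the change (3,4-dimethoxyphenyl in place of 3-fluoro-4-methoxybenzyl on a saturated chain carbon, two bonds along the chain from an oxygen next to a carbonyl group). Going by the values given here, two measured steps bear on parts of this change. The loss of the fluorine is the reverse of a 2.5-fold lower number from compound 2 to compound 3 (0.39 log units; beyond the scatter), which points toward a higher number in this assay. The methoxy next to where the fluorine sat is covered by a 2.0-fold higher number from compound 1 to compound 3 (0.30 log units; within the scatter), which is within the scatter and carries no direction. Among the compounds with values here, the shortened chain and the second methoxy have no measured counterpart in this set, so that part of the change rests on nothing.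

On balance a modest rise in this assay is expected, with the estimated step of a 3.5-fold higher number from compound 3 to compound 4 (0.54 log units; beyond the scatter) and a wide range. Compound 4 is estimated at 900 nM, between 300 nM and 2700 nM.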

Compound 4, inhibition constant: 3490 nM
Estimate against measurement, compound 4: 3.9-fold (0.59 log units) below, outside the stated range (above it).
By their numbers in this assay, from the lowest: compounds 1 and 3 (each within the scatter of the next); then compound 2; then compound 4.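

In this assay, going by these compounds alone, the change at this place, on a saturated chain carbon, two bonds along the chain from an oxygen next to a carbonyl group, gives the first large steps: a 13-fold higher number from compound 3 to compound 4 (1.13 log units; beyond the scatter) and a 27-fold higher number from compound 1 to compound 4 (1.43 log units; beyond the scatter), which leave compound 4 as the weakest of the four. The rise does not depend on losing the fluorine, since neither compound in the remaining pair carries one and the 3,4-dimethoxyphenyl still gives a 5.5-fold higher number from compound 2 to compound 4 (0.74 log units; beyond the scatter). The data at hand offer no measurement that explains the size of these steps.

On these data alone, compound 4 differs from the others in both the shorter chain and the second methoxy, so the share of each remains open; a 4-methoxyphenyl or a 3-fluoro-4-methoxyphenyl on the same chain, or a 3,4-dimethoxybenzyl on the longer one, would separate them. Also open, as far as these compounds go, is how this place responds to groups of another kind, such as an amine or a carboxylic acid on the aromatic ring, or to a still longer chain.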